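The source may hold more compounds than are shown below. What is called first, only, known or untested is meant among the compounds shown, and "the series" means these compounds.

In a functional assay on SK-MEL-28 cells (Homo sapiens) for inhibition, read by sulforhodamine B assay, with a stated time of 48 h, tested at 0.01 uM (a lower number here means a stronger effect, a higher number a weaker effect of the compound at the concentration tested), compound 2 `COc1cc(Cl)cc(-c2nn(-c3cccc(NC(=O)Nc4cccc(C(F)(F)F)c4)c3)cc2-c2ccncc2)c1` gives 99%, which stands at the top of the two numbers measured. Among the compounds with values here, its only neighbour, compound 1 `COc1cc(Cl)cc(-c2nn(-c3cccc(NC(=O)Nc4ccc(Cl)c(C(F)(F)F)c4)c3)cc2-c2ccncc2)c1`, gives 98% in this assay, and the single measured step, a number 1 percentage points higher from compound 1 to compound 2 (within the scatter), lies within the scatter. Compound 3 `COc1cc(Cl)cc(-c2nn(-c3cccc(NC(=O)c4cccc(C(F)(F)F)c4)c3)cc2-c2ccncc2)c1` differs from compound 2 in one place: 3-(trifluoromethyl)phenyl in place of (3-(trifluoromethyl)phenyl)amino on a carbonyl carbon. Within the data shown here, no measured step touches this carbonyl carbon, and the data hold nothing that points to a move beyond the scatter in this assay. Compound 3 is therefore expected to give 97% in this assay, within 85% to 102%. The expected step is a number 2 percentage points lower from compound 2 to compound 3 (within the scatter).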

Compound 3, a percentage reported as activity, at one concentration (the size of the read-out at that concentration, not a potency): 105%
The estimate for compound 3 lay 8 percentage points below the measured number, and the stated range ends below it.
By their numbers in this assay, from the lowest: compounds 1, 2 and 3 (each within the scatter of the next).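

In this assay, the carbonyl carbon proves open to change: with 3-(trifluoromethyl)phenyl in place of the (3-(trifluoromethyl)phenyl)amino group, the result is a number 6 percentage points higher from compound 2 to compound 3 (within the scatter). The comparison with the chloro-bearing analogue reads the same, a number 7 percentage points higher from compound 1 to compound 3 (within the scatter), so losing the amino nitrogen does not separate these compounds here. No available evidence bears on this result. The compounds shown leave open whether a group of another kind on this carbonyl carbon, such as an alkyl chain or a morpholine, would give a step beyond the scatter.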